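This account rests on a few compounds, and the source may have more. Where it says the series, first, only, none or still open, it means among the compounds named here.

Working notes on the series.

Compound 1 `COc1cc(-c2cc(/C=C/C(=O)c3ccc(N)cc3)[nH]n2)cc(OC)c1OC` is measured in a functional assay on RPMI-8226 cells (Homo sapiens) for inhibition, read by sulforhodamine B assay, with a stated time of 48 h; on this read-out higher numbers stand for lower toxicity in this test and lower numbers for higher toxicity in this test. In this assay compound 1 gives only a limit, > 100000 nM, and no number. Compound 3 `COc1cc(-c2cc(/C=C/C(=O)c3ccc(Cl)c(Cl)c3)[nH]n2)cc(OC)c1OC` likewise gives only a limit in this assay, > 100000 nM. The step that the two limits leave unreadable from compound 1 to compound 3 therefore cannot be read, since both ends sit at the limit (the limit of > 100000 nM in this assay, at which 2 of the 3 values shown sit). Within the data shown here, compound 2 `COc1ccc(-c2cc(/C=C/C(=O)c3ccc(OC)c(OC)c3)[nH]n2)cc1` is the one member of the set that gives a number: in this assay compound 2 gives 8160 nM.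

Compound 4 `COc1ccc(-c2cc(/C=C/C(=O)c3ccc(N)cc3)[nH]n2)cc1OC` differs from compound 1 in one place: hydrogen in place of methoxy on an aromatic carbon. Among the measured compounds shown here, no measured step in this assay touches this change, as the only step between measured compounds that differ in one place is the unreadable one from compound 1 to compound 3, and the gap between compound 1 and compound 2 spans two changes at once. Compound 1 itself stands at the limit of this assay. Any movement for compound 4 can therefore only be guessed from the bare fact that compound 2, carrying fewer methoxy groups on the aryl attached to the core, gives a number, 8160 nM.

For compound 4 the expected result is 60000 nM, with a range from 15000 nM to 200000 nM. The estimated step from compound 1 to compound 4, an at least 1.6-fold lower number from compound 1 to compound 4 (0.22 log units; that floor lies within the scatter), is expected to be small or not readable at all, with a fair chance that compound 4 again returns only a limit.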

Compound 4, concentration lethal to 50% of the cells: > 100000 nM
Compound 4 was reported as a limit; the forecaster's own chance of this, stated with the estimate: 50%; middle value at least 1.6-fold (0.22 log units) away from the limit.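

In this assay compound 4 gives only a limit, > 100000 nM, and the step to it from compound 1 cannot be read, with both ends at the limit: the limit of > 100000 nM in this assay, at which 3 of the 4 values shown sit.

The compounds shown leave open whether hydrogen in place of methoxy on an aromatic carbon changes the read-out at all.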